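A few compounds are considered here, and "the series" means these few. Any claim that something is new, unique, unknown or untested is made for them only; others in the source may bear on it.

Of the compounds shown here, two have been measured in a physicochemical assay, with a stated time of 30 min; a lower number here means that less compound is needed, a higher number that more compound is needed for the effect. Compound 1 `COc1cc(/C=C/C(=O)N2c3cc(O[C@@H]4O[C@H](CO[C@@H]5O[C@H](CO)[C@@H](O)[C@H](O)[C@H]5O)[C@@H](O)[C@H](O)[C@H]4O)c(O)cc3C[C@H]2C(=O)O)ccc1O` gives 40100 nM. Compound 2 `O=C(/C=C/c1ccc(O)c(O)c1)O[C@H]1[C@H](OC[C@H]2O[C@@H](Oc3cc4c(cc3O)C[C@@H](C(=O)O)N4C(=O)/C=C/c3ccc(O)cc3)[C@H](O)[C@@H](O)[C@@H]2O)O[C@H](CO)[C@@H](O)[C@@H]1O` gives 15300 nM, the lowest of the two numbers; its gap to compound 1 lies beyond the usual scatter of repeated measurements.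

Compound 3 `COc1cc(/C=C/C(=O)N2c3cc(O[C@@H]4O[C@H](CO[C@@H]5O[C@H](CO)[C@@H](O)[C@H](O)[C@H]5OC(=O)/C=C/c5ccc(O)c(O)c5)[C@@H](O)[C@H](O)[C@H]4O)c(O)cc3C[C@H]2C(=O)O)ccc1O` has not yet been measured. It differs from compound 2 in one place: methoxy in place of hydrogen on an aromatic carbon. For the measured compounds named here, no pair of measured compounds differs by exactly this change, so there is no measured step to lean on.

The expectation is that the step from compound 2 to compound 3 in this assay will be small, a 1.2-fold higher number from compound 2 to compound 3 (0.09 log units; within the scatter), leaning toward a slightly higher number and staying within or close to the scatter. On that basis compound 3 is estimated at 19000 nM, with a likely range from 8000 nM to 45000 nM.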

Compound 3, half-maximal effective concentration: 16100 nM
For compound 3 the middle estimate is 1.2-fold (0.07 log units) above the measured one, and the stated range covers the measured number.
By their numbers in this assay, from the lowest: compounds 2 and 3 (each within the scatter of the next); then compound 1.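

In this assay, methoxy in place of hydrogen on an aromatic carbon, ortho to a hydroxy group, gives a 1.1-fold higher number from compound 2 to compound 3 (0.02 log units; within the scatter), so going from 4-hydroxyphenyl to 4-hydroxy-3-methoxyphenyl makes no readable difference here, something compounds 1 and 2 alone could not show. Compound 3 also isolates a second change, (2-(3,4-dihydroxyphenyl)ethenyl)carbonyl in place of hydrogen on an oxygen on a saturated carbon, which gives a 2.5-fold lower number from compound 1 to compound 3 (0.40 log units; beyond the scatter), a step beyond the scatter. No measurement available here accounts for either step.

As far as these compounds go, whether a different group at the methoxy position, such as ethoxy or a fluorine atom, would also leave the number within the scatter remains open. From the compounds shown here alone, it is equally open whether a small acetyl group on that oxygen would match the step seen with the larger group.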